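Removing a methoxy group from a salicylaldehyde thiosemicarbazone

This account rests on a few compounds, and the source may have more. Where it says the series, first, only, none or still open, it means among the compounds named here.

Measured compounds:
compound 1, `COc1cccc(/C=N/NC(=S)Nc2ccccc2)c1O`: 1400 nM
compound 2, `CCN(CC)c1ccc(/C=N/NC(N)=S)c(O)c1`: 200 nM

Of the compounds shown here, two have been tested in a functional assay on WI-38 cells (Homo sapiens) for antiproliferative activity, read by MTT assay, with a stated time of 72 h; on this read-out lower numbers stand for stronger inhibition and higher numbers for weaker inhibition. Compound 1 gives 1400 nM in this assay and stands at the higher of the two numbers, that is, it is the weaker inhibitor of the pair. Its nearest neighbour is compound 2, whose number in this assay is 200 nM; the gap between the two lies beyond the scatter. The two structures differ in several places at once, so nothing can be said about which change carries that gap.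

Compound 3, `Oc1ccccc1/C=N/NC(=S)Nc1ccccc1`, has not yet been measured in this assay. It differs from compound 1 by hydrogen in place of methoxy on an aromatic carbon. For the measured compounds named here, no pair of measured compounds shows the effect of this change alone, so the expectation rests only on compound 1 itself. The step from compound 1 to compound 3 in this assay is expected to be small, a 1.1-fold higher number from compound 1 to compound 3 (0.06 log units; within the scatter), most likely within the scatter and with no clear direction. Compound 3 is therefore estimated at 1600 nM in this assay, with a range from 500 nM to 5000 nM.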

Compound 3, half-maximal inhibitory concentration: 1300 nM
Beside the measured number, compound 3's estimate is 1.2-fold (0.09 log units) above it; low and high end bracket the measured number.
By their numbers in this assay, from the lowest: compound 2; then compounds 3 and 1 (each within the scatter of the next).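

With compound 1 and compound 3, this assay now has a pair that differs in one place only, and the step is a 1.1-fold lower number from compound 1 to compound 3 (0.03 log units; within the scatter). On this core, methoxy and hydrogen on this aromatic carbon, ortho to a hydroxy group, therefore cannot be told apart in this read-out, and the methoxy group, with its 2 heavy atoms and its hydrogen-bond acceptor, is not required for a number at this level. Nothing at hand bears on why these two groups read alike.

As far as these compounds go, the result concerns only methoxy and hydrogen, so it remains open whether an amine, a carboxylic acid or a longer chain such as butoxy on this same carbon would also stand level with compound 1 and compound 3. It also leaves open which of the several differences between these two compounds and compound 2 carries the lower number of compound 2, since no single change links compound 2 to either of them.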